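From Methoxy to Chloro in a Small Antiproliferative Series

The source may hold more compounds than are shown below. What is called first, only, known or untested is meant among the compounds shown, and "the series" means these compounds.

In a functional assay on HeLa cells (Homo sapiens) for antiproliferative activity, read by MTT assay, with a stated time of 48 h (a lower number here means a stronger inhibitor, a higher number a weaker inhibitor), compound 1 `Cc1ccc2nc(NC(c3cn(-c4ccccc4)nc3-c3cccc([N+](=O)[O-])c3)c3c(O)ccc4ccccc34)sc2c1` gives 7360 nM and compound 2 `COc1ccc2nc(NC(c3cn(-c4ccccc4)nc3-c3ccc(F)cc3)c3c(O)ccc4ccccc34)sc2c1` gives 4630 nM while compound 3 `COc1ccc2nc(NC(c3cn(-c4ccccc4)nc3-c3cccc([N+](=O)[O-])c3)c3c(O)ccc4ccccc34)sc2c1` gives 6140 nM on the same read-out. Compound 3 stands within the scatter of both of the others.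

Compound 4 `O=[N+]([O-])c1cccc(-c2nn(-c3ccccc3)cc2C(Nc2nc3ccc(Cl)cc3s2)c2c(O)ccc3ccccc23)c1` keeps the rest of compound 3 and changes one group chloro in place of methoxy on an aromatic carbon by placing chloro in place of methoxy on an aromatic carbon, so that 6-methoxy-1,3-benzothiazol-2-yl becomes 6-chloro-1,3-benzothiazol-2-yl. Among the compounds with values here, no measured pair holds this exact exchange. The closest evidence is the exchange of a small group at that same place, a 1.2-fold lower number from compound 1 to compound 3 (0.08 log units; within the scatter) in size. The other measured step, a 1.3-fold higher number from compound 2 to compound 3 (0.12 log units; within the scatter) for a change of aryl group elsewhere on the shared core, shows that this second exchange also stayed inside the scatter. With only these two small steps to go on, no shift beyond the scatter is expected from the new exchange, though a single comparison at this place is thin support. The expected size is a 1.1-fold lower number from compound 3 to compound 4 (0.05 log units; within the scatter) in this assay and is estimated to stay within the scatter. In this assay the estimate for compound 4 is 5500 nM (expected range 2500 nM to 12000 nM).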

Compound 4, half-maximal inhibitory concentration: 15500 nM
Beside the measured number, compound 4's estimate is 2.8-fold (0.45 log units) below it; measured number outside the range, above it.
By their numbers in this assay, from the lowest: compounds 2, 3 and 1 (each within the scatter of the next); then compound 4.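

In this assay, the exchange at this aromatic carbon gives a 2.5-fold higher number from compound 3 to compound 4 (0.40 log units; beyond the scatter), and the same place, with methyl leaving instead of methoxy, gives a 2.1-fold higher number from compound 1 to compound 4 (0.32 log units; beyond the scatter); both steps are modest, but they lie beyond the scatter and point to a weaker inhibitor. The earlier step at this place, a 1.2-fold lower number from compound 1 to compound 3 (0.08 log units; within the scatter), stayed within the scatter, so the series had not yet shown that this position could move the read-out at all; now chloro stands apart from both methoxy and methyl, which do not separate from each other. Nothing shown here accounts for this separation of chloro from the other two groups.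

As far as these compounds go, the comparison rests on three small groups at this place, all alongside the 3-nitrophenyl group on the shared core, so it remains open whether chloro would shift the number in the same way alongside the 4-fluorophenyl group of compound 2. From the compounds shown here alone, it is also open how an amine or a carboxylic acid at this aromatic carbon would stand against methoxy, methyl and chloro.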